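This account rests on a few compounds, and the source may have more. Where it says the series, first, only, none or still open, it means among the compounds named here.

Of the compounds shown here, two have been measured for cytotoxicity so far. Compound 1 `Cc1nc(C)n(-c2nc(-c3ccccc3)cc(=O)[nH]2)n1` and compound 2 `CCc1cc(C)nn1-c1nc(C(F)(F)F)cc(=O)[nH]1` share a common core and differ in the groups attached to it. In an ADME assay on CHO cells (Cricetulus griseus) for cytotoxicity, read by MTT assay (a higher number here means a weaker inhibitor, a lower number a stronger inhibitor), compound 1 gives > 50000 nM, which is a limit of the assay rather than a number. In this assay compound 2 gives 108000 nM, and this is the only number shown. The remaining value is the limit of > 50000 nM in this assay, at which 1 of the 2 values shown sits. Compound 3 `COCCNc1cc(C)nn1-c1nc(C(F)(F)F)cc(=O)[nH]1` has not yet been measured. It differs from compound 2 by (2-methoxyethyl)amino in place of ethyl on an aromatic carbon. Among the measured compounds shown here, no step between measured compounds is available to show how such a change behaves in this setting. Since compound 2 is already a weak inhibitor at 108000 nM, the step from compound 2 to compound 3 is expected to be small or none beyond the scatter, in either direction. The estimate for compound 3 in this assay is 100000 nM, with a range from 40000 nM to 250000 nM. The expected step is a 1.1-fold lower number from compound 2 to compound 3 (0.03 log units; within the scatter).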

Compound 3, half-maximal inhibitory concentration: 17000 nM
Beside the measured number, compound 3's estimate is 5.9-fold (0.77 log units) above it; measured number below the stated range.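

Putting (2-methoxyethyl)amino in place of ethyl on this aromatic carbon of the five-membered ring gives a 6.4-fold lower number from compound 2 to compound 3 (0.80 log units; beyond the scatter) in this assay. Among the compounds shown here, this is the first sign that the group at this position can move the result beyond the scatter, and it moves it towards stronger inhibition, although the step is only modest. The entering group differs from ethyl in several ways at once, with more heavy atoms, a nitrogen, an oxygen, and hydrogen-bond donor and acceptor counts that ethyl lacks, so this single step cannot show which of these differences matters.

From the compounds shown here alone, it remains open whether the step follows from the nitrogen, the oxygen or the longer chain, and groups such as a plain butyl chain, a methylamino group or a 2-hydroxyethylamino group at this place would help to separate these. Compound 1 cannot settle this, because it differs from the other two in more than one place and its value is a limit of the assay rather than a number: the limit of > 50000 nM in this assay, at which 1 of the 3 values shown sits.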